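Changing the Amide Substituent toward a Hydroxyethyl Group

The compounds below may be only part of what the source reports. "The series", "measured", "known", "first", "only" and "open" are said of these compounds alone.

Three compounds built on one shared core have been tested in a functional assay on the whole organism (strain Wistar) for inhibition, with Rattus norvegicus as the target, read by paw edema, with stated times of 60 min and 1 h, at a dose of 100 mg/kg by the oral route; on this read-out lower numbers stand for less inhibition and higher numbers for more inhibition at the one dose given (going by the name of the read-out):

Compound 1, `CCCNC(=O)CC1CCc2cc(OC)c(OC)cc21`, gives 18.8%.
Compound 2, `COc1cc2c(cc1OC)C(CC(=O)NC(C)(C)C)CC2`, gives 31.3%.
Compound 3, `CCCCCNC(=O)CC1CCc2cc(OC)c(OC)cc21`, gives 34.4%.

Compound 2 stands second highest of these three numbers. Compound 3 sits nearest, the step of a number 3.1 percentage points higher from compound 2 to compound 3 (within the scatter) lying within the scatter, so the two cannot be ordered. Compound 1 sits furthest, and the step of a number 12.5 percentage points higher from compound 1 to compound 2 (beyond the scatter) lies beyond the scatter.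

Compound 4, `COc1cc2c(cc1OC)C(CC(=O)NCCO)CC2`, differs from compound 2 by 2-hydroxyethyl in place of tert-butyl on an amide-type nitrogen. All three measured steps also alter the group on the amide nitrogen, so they bear on this change, though none of them brings in an oxygen or a hydrogen-bond donor. Two of them, a number 12.5 percentage points higher from compound 1 to compound 2 (beyond the scatter) and a number 15.6 percentage points higher from compound 1 to compound 3 (beyond the scatter), show that the group with more carbon atoms went with the higher number, while a number 3.1 percentage points higher from compound 2 to compound 3 (within the scatter) shows no difference beyond the scatter. For the measured compounds named here, the incoming 2-hydroxyethyl group carries fewer heavy atoms than tert-butyl, which points toward a lower number for compound 4, but the hydroxyl group has no measured counterpart here, so the expectation is loose. The estimated step is a number 9.3 percentage points lower from compound 2 to compound 4 (within the scatter), a modest fall, with a range wide enough to include no change. Compound 4 is expected to give about 22%, between 8% and 38%.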

Compound 4, a percentage reported as inhibition, in the whole organism at one dose (the size of the read-out at that dose, not a potency): 0%
Compound 4: middle estimate off by 22 percentage points, on the high side; measured number outside the range, below it.
By their numbers in this assay, from the lowest: compound 4; then compound 1; then compounds 2 and 3 (each within the scatter of the next).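

In this assay, every carbon group on this amide nitrogen gives a higher number than 2-hydroxyethyl, whether the comparison is with tert-butyl (a number 31.3 percentage points lower from compound 2 to compound 4 (beyond the scatter)), with pentyl through hydroxy in place of propyl (a number 34.4 percentage points lower from compound 3 to compound 4 (beyond the scatter)), or with propyl through hydroxy in place of methyl (a number 18.8 percentage points lower from compound 1 to compound 4 (beyond the scatter)). The last of these is the smallest change in the set, yet even from the lowest of the carbon-substituted compounds it leads to the bottom of the series, with compound 4 at (0%), so this position accepts the straight and branched carbon groups shown but not this hydroxy-bearing chain. Nothing available here accounts for this fall, and the whole-animal number alone does not explain it.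

On these data alone, what stays open is whether the fall follows the hydroxy group itself or its place on the chain, a question that 2-methoxyethyl or 3-hydroxypropyl on the same nitrogen would help to settle. As far as these compounds go, it is also open whether other heteroatom-bearing groups, such as 2-aminoethyl or a chain ending in a carboxylic acid, would fall as far as compound 4.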